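A few compounds are considered here, and "the series" means these few. Any claim that something is new, unique, unknown or untested is made for them only; others in the source may bear on it.

Measured compounds in an assay on isolated protein for inhibition of long-chain fatty acid transport protein 1 (Homo sapiens); on this read-out higher numbers stand for weaker inhibition and lower numbers for stronger inhibition:
compound 1, `CCC(=O)c1ccc(N(C)C(=O)CSc2nnc(CNc3ccccc3)n2CC)cc1`: 580 nM
compound 2, `CCn1c(CNc2ccccc2)nnc1SCc1nc2cc(F)ccc2o1`: > 1000 nM
compound 3, `CCn1nnc(-c2ccc(NC(=O)CSc3nnc(CNc4ccccc4)n3CC)cc2)n1`: > 1000 nM

Compound 2 gives only a limit in this assay, > 1000 nM. That limit is the limit of > 1000 nM in this assay, at which 2 of the 3 values shown sit, so compound 2 has no resolved number here, only the statement that it was not resolved. Going by the values given here, compound 1 carries a resolved value, but no step between compound 1 and compound 2 has been worked out; the two values show merely that compound 1 is resolved and compound 2 is not.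

Compound 4, `CCC(O)c1ccc2oc(CSc3nnc(CNc4ccccc4)n3CC)nc2c1`, is not yet measured. It differs from compound 2 in one place: 1-hydroxypropyl in place of fluoro on an aromatic carbon. With compound 2 at a limit, any step from it can only be judged by whether compound 4 comes back resolved. The expected step in this assay is a step that the limit leaves unreadable from compound 2 to compound 4, that is, none clearly beyond the scatter, with a fair chance of a limit again. For compound 4 the estimate is 1500 nM, expected between 600 nM and 5000 nM.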

Compound 4, half-maximal inhibitory concentration: > 1000 nM
Compound 4 ended at the assay's limit; the forecaster's own chance of this, stated with the estimate: 55%; the middle value does not contradict the limit.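

No step from compound 2 to compound 4 can be read in this assay, as both compounds end at a limit of the assay: the limit of > 1000 nM in this assay, at which 3 of the 4 values shown sit.

On these data alone, whether 1-hydroxypropyl in place of fluoro on an aromatic carbon changes inhibition at all, and in which direction, stays open.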